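Taking the Methoxy Off Compound 1

This account rests on a few compounds, and the source may have more. Where it says the series, first, only, none or still open, it means among the compounds named here.

Compound 1 `COc1ccc(Cc2cn3cc(Br)ccc3nc2=O)cc1` is known only by a limit. In a functional assay on MCF7 cells (Homo sapiens) for cytotoxicity, read by MTT assay, with a stated time of 24 h (a higher number here means a weaker inhibitor, a lower number a stronger inhibitor), compound 1 gives > 1000000 nM, which is a limit of the assay and not a number. Compound 2 `O=c1nc2ccc(Cl)cn2cc1Cc1ccc(F)cc1` does give a number, as compound 2 reads 10400 nM. Compound 3 `O=c1nc2ccc(Br)cn2cc1Cc1ccccc1` has not yet been measured. Its structure differs from compound 1 in one place: hydrogen in place of methoxy on an aromatic carbon. In words, hydrogen stands in place of methoxy on an aromatic carbon. Among the compounds with values here, no measured pair shows this change on its own, so the size of the step remains uncertain. With compound 2 at 10400 nM, a real number seems likely here too, so a large move towards stronger inhibition is expected. The expected step is an at least 25-fold lower number from compound 1 to compound 3 (1.39 log units; beyond the scatter). For compound 3 the estimated value is 40000 nM, with an expected range of 6000 nM to 300000 nM.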

Compound 3, half-maximal inhibitory concentration: > 1000000 nM
Compound 3 was reported as a limit; the forecaster's own chance of this, stated with the estimate: 25%; at least 25-fold (1.39 log units) between middle value and limit.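

Compound 1 and compound 3 both end at a limit rather than a number, so the step between them cannot be read: the limit of > 1000000 nM in this assay, at which 2 of the 3 values shown sit.

The compounds shown leave open whether hydrogen in place of methoxy changes the true value at all, and by how much.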